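Shifting an Ethoxy Group on the Phenyl of Compound 2

The source may hold more compounds than are shown below. What is called first, only, known or untested is meant among the compounds shown, and "the series" means these compounds.

Measured compounds:
- compound 1 `N#CC1=C(N)Oc2c(N)cc3nc4ccccc4nc3c2C12C(=O)N(Cc1cnnn1-c1ccc(Cl)cc1)c1ccccc12`: > 50000 nM
- compound 2 `CCOc1ccc(-n2nncc2CN2C(=O)C3(C(C#N)=C(N)Oc4c(N)cc5nc6ccccc6nc5c43)c3ccccc32)cc1`: > 50000 nM

Compound 1 and compound 2 were both tested in an ADME assay on L02 cells (Homo sapiens) for antiproliferative activity, read by MTT assay, with a stated time of 48 h; a higher number here means a weaker inhibitor, a lower number a stronger inhibitor. For compound 1 the result is only a limit of the assay, > 50000 nM. For compound 2 the result is likewise only a limit, > 50000 nM. Within the data shown here, the single measured step, a step that the two limits leave unreadable from compound 1 to compound 2, cannot be read because both values sit at the limit of > 50000 nM in this assay, at which 2 of the 2 values shown sit. Compound 2 therefore stands at the edge of what the assay reports, with no numerical value placing it on a scale.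

Compound 3 `CCOc1ccccc1-n1nncc1CN1C(=O)C2(C(C#N)=C(N)Oc3c(N)cc4nc5ccccc5nc4c32)c2ccccc21` is not yet measured. It differs from compound 2 in one respect: 2-ethoxyphenyl in place of 4-ethoxyphenyl on an aromatic nitrogen. No measured step bears directly on this change, and the only step shown is itself unreadable. What is known is that compound 2 sits at the limit of > 50000 nM in this assay, at which 2 of the 2 values shown sit. The step that the limit leaves unreadable from compound 2 to compound 3 is therefore expected to be no larger than the usual scatter. Compound 3 is estimated at 60000 nM, with a range from 30000 nM to 150000 nM, and the assay is expected most likely to report a limit again.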

Compound 3, half-maximal inhibitory concentration: > 50000 nM
Compound 3 gave a limit, no number; the forecaster's own chance of this, stated with the estimate: 80%; the middle value is on the limit's open side.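

No step among compound 1, compound 2 and compound 3 can be read, because all three results are only limits of the assay: the limit of > 50000 nM in this assay, at which 3 of the 3 values shown sit.

In this assay, going by these compounds, none of the three compounds carries a number, so it stays open whether 4-chlorophenyl, 4-ethoxyphenyl and 2-ethoxyphenyl on the aromatic nitrogen differ at all.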